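Sulfanyl in place of sulfonyl: expected acid dissociation of compound 4

The compounds below may be only part of what the source reports. "The series", "measured", "known", "first", "only" and "open" are said of these compounds alone.

In a physicochemical assay for acid dissociation, compound 3 `COC(=O)c1cc(S(N)(=O)=O)ccc1S(=O)(=O)CCO` gives 9.2, the lowest of the three numbers. Compound 1 `NS(=O)(=O)c1ccc(SCCCO)c(Cl)c1` gives 9.45, and compound 2 `NS(=O)(=O)c1ccc(SCCCO)c(F)c1` gives 9.64. The value of compound 3 lies within the scatter of that of compound 1 and beyond the scatter of that of compound 2. Compound 4 `COC(=O)c1cc(S(N)(=O)=O)ccc1SCCCO` differs by (3-hydroxypropyl)sulfanyl in place of (2-hydroxyethyl)sulfonyl on an aromatic carbon, ortho to a methoxycarbonyl group and para to a sulfamoyl group. For the measured compounds named here, no measured step covers this exchange. The only one, a number 0.19 log units higher from compound 1 to compound 2 (within the scatter), concerns another place and stays within the scatter. Compound 1 at 9.45 and compound 2 at 9.64 carry the incoming (3-hydroxypropyl)sulfanyl group, so a small upward move in this assay is expected. The estimated step is a number 0.30 log units higher from compound 3 to compound 4 (within the scatter). For compound 4 the expected value is 9.5, with an estimated range of 9.25 to 9.75.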

Compound 4, acid dissociation constant: 9.3
Compound 4: middle estimate off by 0.20 log units, on the high side, and the stated range covers the measured number.
By their numbers in this assay, from the lowest: compounds 3, 4, 1 and 2 (each within the scatter of the next, the first and the last beyond it).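

In this assay the exchange at this position, (3-hydroxypropyl)sulfanyl in place of (2-hydroxyethyl)sulfonyl, gives a number 0.10 log units higher from compound 3 to compound 4 (within the scatter) and so does not separate the two groups. Methoxycarbonyl in place of fluoro gives a number 0.34 log units lower from compound 2 to compound 4 (beyond the scatter) whereas methoxycarbonyl in place of chloro gives a number 0.15 log units lower from compound 1 to compound 4 (within the scatter) so only the comparison with fluoro is resolved. The sulfur group and the chain change together here, so the separate contribution of each stays open; a (2-hydroxyethyl)sulfanyl group would divide them, and an amine at this position is also untested in the compounds shown. No supporting data bear on the reason for these steps.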